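Selenocyanate side chain of compound 3 lengthened through an oxygen

The source may hold more compounds than are shown below. What is called first, only, known or untested is meant among the compounds shown, and "the series" means these compounds.

The series shares one core. Compound 1 `COc1ccc(N(C)c2nc(C)nc3ccccc23)cc1C(=O)OCCC[Se]C#N` gives 1140 nM in a functional assay on RKO cells (Homo sapiens) for inhibition, read by MTT assay, with a stated time of 48 h; on this read-out higher numbers stand for weaker inhibition and lower numbers for stronger inhibition; compound 2 `COc1ccc(N(C)c2nc(C)nc3ccccc23)cc1C(=O)OCC[Se]C#N` gives 2390 nM; compound 3 `COc1ccc(N(C)c2nc(C)nc3ccccc23)cc1C[Se]C#N` gives 316 nM, the lowest of the three numbers. Within the measured set, a 3.6-fold lower number from compound 1 to compound 3 (0.56 log units; beyond the scatter) and a 7.6-fold lower number from compound 2 to compound 3 (0.88 log units; beyond the scatter), while a 2.1-fold higher number from compound 1 to compound 2 (0.32 log units; beyond the scatter). Compound 4 `COc1ccc(N(C)c2nc(C)nc3ccccc23)cc1OCC[Se]C#N` differs from compound 3 in that (a group of 6 heavy atoms (3 carbon, 1 nitrogen, 1 oxygen, 1 selenium; no ring) in place of a group of 4 heavy atoms (2 carbon, 1 nitrogen, 1 selenium; no ring), on an aromatic carbon). The chain of compound 4 is longer than that of compound 3 yet shorter than the chains of compound 1 and compound 2, whose numbers in this assay were higher, so a step upward of modest size is expected. Compound 4 is therefore estimated at 700 nM, in a range of 250 nM to 2000 nM, which would be a 2.2-fold higher number from compound 3 to compound 4 (0.35 log units; beyond the scatter).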

Compound 4, half-maximal inhibitory concentration: 27 nM
Compound 4: middle estimate off by 26-fold (1.41 log units), on the high side; the whole stated range lies above it.
By their numbers in this assay, from the lowest: compound 4; then compound 3; then compound 1; then compound 2.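

Among the earlier compounds, the shortest group on this aromatic carbon gave the lowest number, but compound 4 goes against that pattern: its group is larger than that of compound 3, yet this assay shows a 12-fold lower number from compound 3 to compound 4 (1.07 log units; beyond the scatter). Its oxygen-linked chain also far outperforms both ester-linked chains, with an 89-fold lower number from compound 2 to compound 4 (1.95 log units; beyond the scatter) and a 42-fold lower number from compound 1 to compound 4 (1.63 log units; beyond the scatter), so group size alone does not order these numbers. Nothing available here explains this change. As far as these compounds go, whether a longer chain on the same oxygen, or an amine in place of that oxygen, would keep the number this low remains open.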